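A Chloro Added to the Phenyl Ring of Compound 1

The source may report more compounds than this note shows. Statements on the series, on what has been measured and on what is new or still open speak of the compounds shown alone.

Compound 1 `O=C(Nc1cccc(/C=C/C(=O)c2nc3ccccc3[nH]2)c1)c1ccccc1` is the starting point of this comparison. Within the data shown here, in a functional assay on MCF7 cells (Homo sapiens) for antiproliferative activity, read by MTT assay, with a stated time of 48 h (on this read-out higher numbers stand for weaker inhibition and lower numbers for stronger inhibition), compound 1 gives 11200 nM, the highest of the two numbers measured so far. Among the measured compounds shown here, the only measured neighbour is compound 2 `O=C(/C=C/c1cccc(NC(=O)c2ccccc2Cl)c1)c1nc2ccccc2[nH]1`, which in this assay gives 4570 nM; the step of a 2.5-fold lower number from compound 1 to compound 2 (0.39 log units; beyond the scatter) comes with chloro in place of hydrogen on an aromatic carbon of the same phenyl ring.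

Compound 3 `O=C(Nc1cccc(/C=C/C(=O)c2nc3ccccc3[nH]2)c1)c1cccc(Cl)c1` differs from compound 1 by chloro in place of hydrogen on an aromatic carbon. Here the chloro sits meta to a large group, so the phenyl becomes 3-chlorophenyl and the benzoyl becomes (3-chlorophenyl)carbonyl. For the measured compounds named here, only one measured step bears on this change, the one from compound 1 to compound 2, where a chloro entered the same ring at a different place and gave a modest lowering beyond the scatter. Because of a 2.5-fold lower number from compound 1 to compound 2 (0.39 log units; beyond the scatter) a step of similar size and direction is expected for compound 3, though the other position leaves room for doubt. For compound 3 the expected step is a 2.2-fold lower number from compound 1 to compound 3 (0.35 log units; beyond the scatter). Compound 3 is therefore estimated at 5000 nM, with a range from 2000 nM to 14000 nM.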

Compound 3, half-maximal inhibitory concentration: 7840 nM
For compound 3 the middle estimate is 1.6-fold (0.20 log units) below the measured one; low and high end bracket the measured number.
By their numbers in this assay, from the lowest: compounds 2, 3 and 1 (each within the scatter of the next, the first and the last beyond it).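

In this assay, the chloro of the 3-chlorophenyl group gives a step that cannot be told apart from no change at all: a 1.4-fold lower number from compound 1 to compound 3 (0.15 log units; within the scatter) is the reading, so on these numbers compound 3 and the plain phenyl of compound 1 sit together. Among these compounds, the two chloro placements cannot be separated either, as a 1.7-fold higher number from compound 2 to compound 3 (0.23 log units; within the scatter) shows, which leaves compound 3 within the scatter of both neighbours, while the only step beyond the scatter remains the one with the 2-chlorophenyl group, a 2.5-fold lower number from compound 1 to compound 2 (0.39 log units; beyond the scatter) in this set. Nothing here offers a measured reason for any of these numbers, so the small differences stay plain observations.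

With only a hydrogen and a chloro compared on this ring, and steps this small, the compounds give no sense of how far the read-out can move through this position. As far as these compounds go, whether a fluoro, a methoxy group or an amine on the same phenyl ring would give a larger step, or one in the opposite direction, remains open.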